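Ester chain extension in the furan-3-yl member of the series

The compounds below may be only part of what the source reports. "The series", "measured", "known", "first", "only" and "open" are said of these compounds alone.

Measured compounds and their values in an assay on cells for displacement of a labelled ligand from adenosine receptor A1 (Homo sapiens), with a stated time of 60 min, tested at 1 uM; on this read-out higher numbers stand for more inhibition at the one concentration tested (going by the name of the read-out) and lower numbers for less inhibition:
compound 1 `CC1=C(C(=O)OC(C)C)C(c2ccccc2)N/C(=N/C#N)N1`, 20%
compound 2 `CC1=C(C(=O)OC(C)C)C(c2ccco2)N/C(=N/C#N)N1`, 21%
compound 3 `CCOC(=O)C1=C(C)N/C(=N\C#N)NC1c1ccoc1`, 28%

Compound 3 gives the highest of the three numbers, but its gaps to compound 2 and compound 1 are both within the scatter, so no order can be claimed among them. Among the measured compounds shown here, the one step between measured compounds is a number 1 percentage points higher from compound 1 to compound 2 (within the scatter), a swap of the aryl group; it does not touch the ester and has no bearing on the change now in question.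

Compound 4 `CC1=C(C(=O)OC(C)C)C(c2ccoc2)N/C(=N/C#N)N1` differs from compound 3 by methyl in place of hydrogen on a saturated chain carbon bound to an oxygen next to a carbonyl group and a saturated chain carbon. For the measured compounds named here, no measured step covers this change, so the expectation for compound 4 is a step of a number 2 percentage points lower from compound 3 to compound 4 (within the scatter), within the scatter. Compound 4 is estimated at 26%, with a range from 12% to 40%.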

Compound 4, a percentage reported as inhibition, at one concentration (the size of the read-out at that concentration, not a potency): 34%
Compound 4: middle estimate off by 8 percentage points, on the low side; low and high end bracket the measured number.
By their numbers in this assay, from the lowest: compounds 1, 2, 3 and 4 (each within the scatter of the next, the first and the last beyond it).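

In this assay, isopropoxycarbonyl in place of ethoxycarbonyl gives a number 6 percentage points higher from compound 3 to compound 4 (within the scatter) and does not separate the two esters. With isopropoxycarbonyl held, the aryl group now registers: furan-3-yl in place of furan-2-yl gives a number 13 percentage points higher from compound 2 to compound 4 (beyond the scatter) and furan-3-yl in place of phenyl gives a number 14 percentage points higher from compound 1 to compound 4 (beyond the scatter) while the earlier aryl swap gave a number 1 percentage points higher from compound 1 to compound 2 (within the scatter) and no separation. No measurement at hand accounts for these differences.

Open, from the compounds shown here alone, is whether a longer chain such as butoxycarbonyl, or a carboxylic acid in place of the ester, moves the number beyond the scatter. Also open, going by these compounds, is whether the furan-3-yl advantage holds with ethoxycarbonyl.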